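From Trifluoromethyl to Nitro on the Benzyl Ring

The compounds below may be only part of what the source reports. "The series", "measured", "known", "first", "only" and "open" are said of these compounds alone.

Compound 1 `FC(F)(F)c1ccc(COc2cccc(Nc3ncnc4cc5c(cc34)OCCOCCOCCO5)c2)cc1` was tested in a functional assay on A549 cells (Homo sapiens) for antiproliferative activity, read by MTT assay, with a stated time of 72 h (a higher number here means a weaker inhibitor, a lower number a stronger inhibitor), where compound 1 gives 24900 nM. Within the data shown here, that is the highest of the two numbers known here. Compound 2 `c1ccc(COc2ccccc2Nc2ncnc3cc4c(cc23)OCCOCCOCCO4)cc1` gives 6940 nM in this assay. Compound 3 `FC(F)(F)c1ccc(COc2ccccc2Nc2ncnc3cc4c(cc23)OCCOCCOCCO4)cc1` reaches only a limit of this assay, > 100000 nM, so for compound 3 no number is known (the limit of > 100000 nM in this assay, at which 1 of the 3 values shown sits). Among the measured compounds shown here, the single measured step between compounds differing in one place, an at least 14-fold higher number from compound 2 to compound 3 (1.15 log units; beyond the scatter), concerns trifluoromethyl in place of hydrogen and a benzyl ether attached elsewhere, so it does not directly test the change considered now.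

Compound 4 `O=[N+]([O-])c1ccc(COc2cccc(Nc3ncnc4cc5c(cc34)OCCOCCOCCO5)c2)cc1` has not yet been measured. It differs from compound 1 in one place: nitro in place of trifluoromethyl on an aromatic carbon. For the measured compounds named here, no measured pair shows nitro replacing trifluoromethyl, so neither direction is supported by the data, and a step within the scatter or a modest move either way is equally plausible. Compound 4 is therefore expected to give about 20000 nM in this assay, somewhere between 5000 nM and 80000 nM. The step this estimate implies, a 1.2-fold lower number from compound 1 to compound 4 (0.10 log units; within the scatter), is an expectation only.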

Compound 4, half-maximal inhibitory concentration: > 100000 nM
Compound 4 was reported as a limit (the forecaster's own chance of this, stated with the estimate: 15%); at least 5.0-fold (0.69 log units) between middle value and limit.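

The exchange of trifluoromethyl for nitro on this benzyl ring gives an at least 4.0-fold higher number from compound 1 to compound 4 (0.60 log units; beyond the scatter) in this assay, so this place on the ring is sensitive to the group it carries, and nitro is the poorer of these two groups here. In the same assay, compound 4 gives > 100000 nM, which is a limit and not a number. This limit now recurs in the series: the limit of > 100000 nM in this assay, at which 2 of the 4 values shown sit.

Still open, on these data alone, is what a methoxy group, an amine or a carboxylic acid would give at this place on the ring of compound 1, and whether any group there would give a lower number than trifluoromethyl. Equally open, as far as these compounds go, is whether nitro would have a similar effect on a benzyl ring attached as in compound 2.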